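The compounds below may be only part of what the source reports. "The series", "measured", "known", "first", "only" and "open" are said of these compounds alone.

Compound 1 `COc1cc(NCc2ccc(Cl)s2)ccc1-c1cnco1` carries a 5-chlorothiophen-2-yl methyl group on the aniline nitrogen of the shared core. In an ADME assay on Huh-7 cells (Homo sapiens) for cytotoxicity, read by MTT assay, with a stated time of 96 h (on this read-out higher numbers stand for lower toxicity in this test and lower numbers for higher toxicity in this test), compound 1 gives 43200 nM, the highest of the two numbers recorded, with compound 3 `COc1cc(NCc2cc(OC)c(OC)c(OC)c2)ccc1-c1cnco1` at 36600 nM lying within the scatter of it. Compound 2 `COc1ccc(-c2cnco2)cc1NCc1cccs1` gives only a limit in this assay, > 100000 nM, which is the limit of > 100000 nM in this assay, at which 1 of the 3 values shown sits. Compound 4 `COc1cc(NCc2ccsc2)ccc1-c1cnco1` is not yet measured; against compound 1 the change is thiophen-3-yl in place of 5-chlorothiophen-2-yl on a saturated chain carbon bound to a nitrogen on an aromatic ring. For the measured compounds named here, no measured step covers this change, so the expected step in this assay is read from compound 2, whose limit > 100000 nM follows removal of the chlorine from a thiophene; a small move toward lower toxicity is expected, close to the scatter. Compound 4 is therefore estimated at 60000 nM, between 30000 nM and 100000 nM, a step of a 1.4-fold higher number from compound 1 to compound 4 (0.14 log units; within the scatter).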

Compound 4, half-maximal cytotoxic concentration: 63100 nM
The estimate for compound 4 lay 1.1-fold (0.02 log units) below the measured number; the measured number falls inside the stated range.
By their numbers in this assay, from the lowest: compounds 3, 1 and 4 (each within the scatter of the next). At a limit, above all of these: compound 2.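

In this assay, for the compounds shown here, the only step at this place, on a saturated chain carbon bound to a nitrogen on an aromatic ring, is a 1.5-fold higher number from compound 1 to compound 4 (0.16 log units; within the scatter), so replacing 5-chlorothiophen-2-yl with thiophen-3-yl leaves the read-out within the scatter. The chlorine and the point of attachment on the thiophene change together in this step, and the two cannot be separated. No measured property here accounts for the step. Still open, as far as these compounds go, is whether a piperidine amine or a carboxylic acid on the chain would move the number beyond the scatter.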